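The source may hold more compounds than are shown below. What is called first, only, known or untested is meant among the compounds shown, and "the series" means these compounds.

Compound 1 `CCCCCCCc1cn(C(c2ccccc2)c2cc3cc(Br)ccc3nc2OC)nn1` gives 0.17%
Compound 2 `CCCCCCc1cn(C(c2ccccc2)c2cc3cc(Br)ccc3nc2OC)nn1` gives -3.17%
Compound 3 `COc1nc2ccc(Br)cc2cc1C(c1ccccc1)n1cc(CO)nn1` gives 11.5%

Of the compounds shown here, three sharing one core have been tested in an ADME assay on HEK293 cells (Homo sapiens) for cytotoxicity, read by sulforhodamine B assay, with a stated time of 48 h, tested at 10 uM; a higher number here means more inhibition at the concentration tested (going by the name of the read-out), a lower number less inhibition. Compound 3 stands highest of the three numbers: the rise a number 11.3 percentage points higher from compound 1 to compound 3 (beyond the scatter) and the rise a number 14.7 percentage points higher from compound 2 to compound 3 (beyond the scatter) are both beyond the scatter, whereas a number 3.3 percentage points lower from compound 1 to compound 2 (within the scatter) stays within it, so compounds 1 and 2 cannot be told apart.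

The next compound, compound 4 `COc1nc2ccc(Br)cc2cc1C(c1ccccc1)n1cc(CCCCCO)nn1`, differs from compound 3 in one place: 4-hydroxybutyl in place of hydroxy on a saturated chain carbon bound to an aromatic carbon. Among the measured compounds shown here, the steps that bear on this are the two that put hydroxy in place of a hexyl or a pentyl chain, each giving a modest rise in this assay. Compound 4 keeps the hydroxy but sets it at the end of a four-carbon chain, so it sits between compound 3 and the chain-bearing compounds 1 and 2. Because the chain-bearing compounds gave the lower numbers 0.17% for compound 1 and -3.17% for compound 2, a small downward step is expected, likely no larger than the scatter. The expected step is a number 6.5 percentage points lower from compound 3 to compound 4 (within the scatter). For compound 4 the estimate in this assay is 5%, with a range from -8% to 18%.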

Compound 4, a percentage reported as inhibition, at one concentration (the size of the read-out at that concentration, not a potency): 7.96%
The estimate for compound 4 lay 3 percentage points below the measured number, and the stated range covers the measured number.
By their numbers in this assay, from the lowest: compounds 2, 1, 4 and 3 (each within the scatter of the next, the first and the last beyond it).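

In this assay, 4-hydroxybutyl in place of hydroxy on a saturated chain carbon bound to an aromatic carbon gives a number 3.5 percentage points lower from compound 3 to compound 4 (within the scatter), so at this position the longer chain ending in hydroxy cannot be told apart from the shorter one. Compared with the chains that carry no hydroxy, the picture is split: a number 11.1 percentage points higher from compound 2 to compound 4 (beyond the scatter) is a modest step, while a number 7.8 percentage points higher from compound 1 to compound 4 (within the scatter) is not a step that can be told from repeat-to-repeat variation, so the hydroxy at the chain end separates compound 4 from only one of the two plain chains. No measurement shown here offers a reason for these numbers.

From the compounds shown here alone, whether an amine or a carboxylic acid at the end of the same chain would read like the hydroxy remains open, as does the reading for a hydroxy carried on a chain longer than 4-hydroxybutyl. All of these readings also come from a single concentration, so they leave open how any of these compounds would behave at other concentrations.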